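Pentylcarbonyl to (tert-butyl)carbonyl: compound 3 to compound 4

This account rests on a few compounds, and the source may have more. Where it says the series, first, only, none or still open, it means among the compounds named here.

Of the compounds shown here, three have been measured. Compound 1 `CC(=O)OCc1ccc2oc(=O)c(C(=O)Sc3cccc(Br)c3)cc2c1` gives 67.8% in a functional assay on HT-1080 cells (Homo sapiens), read by transwell migration, with a stated time of 24 h, tested at 10 uM; on this read-out lower numbers stand for a stronger effect and higher numbers for a weaker effect at the one concentration tested. Compound 2 `CCC(=O)OCc1ccc2oc(=O)c(C(=O)Oc3cccc(Br)c3)cc2c1` gives 21.3% in this assay, and compound 3 `CCCCCC(=O)OCc1ccc2oc(=O)c(C(=O)Oc3cccc(Br)c3)cc2c1` gives 33.9%. Compound 3 thus stands second highest of the three numbers, nearest compound 2 and furthest from compound 1. Compound 4 `CC(C)(C)C(=O)OCc1ccc2oc(=O)c(C(=O)Oc3cccc(Br)c3)cc2c1` differs from compound 3 by tert-butyl in place of pentyl on a carbonyl carbon. Within the data shown here, the one measured step at this part of the molecule is a number 12.6 percentage points higher from compound 2 to compound 3 (beyond the scatter), where the longer chain came with a higher number. Among the measured compounds shown here, compound 4 removes part of that chain, so a modest drop back toward compound 2 is expected, though no measured step covers branching. The expected step is a number 5.9 percentage points lower from compound 3 to compound 4 (within the scatter). Compound 4 is estimated at 28%, in the range 14% to 44%.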

Compound 4, a percentage reported as activity, at one concentration (the size of the read-out at that concentration, not a potency): 23.6%
The estimate for compound 4 lay 4.4 percentage points above the measured number, and the stated range covers the measured number.
By their numbers in this assay, from the lowest: compounds 2 and 4 (each within the scatter of the next); then compound 3; then compound 1.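

On this carbonyl carbon in this assay, branching separates two similar alkyl groups: a number 10.3 percentage points lower from compound 3 to compound 4 (beyond the scatter). Tert-butyl and ethyl are not told apart, with a number 2.3 percentage points higher from compound 2 to compound 4 (within the scatter), so among compounds 2, 3 and 4 only the pentyl compound stands apart, and a larger group does not by itself give a higher number. Nothing available explains the difference between pentyl and tert-butyl. Open, from the compounds shown here alone, is whether a longer straight chain such as octyl, or a cyclohexyl ring, would follow pentyl or tert-butyl here. Also open, going by these compounds, is how tert-butyl behaves on the sulfur-linked core of compound 1.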